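The source may report more compounds than this note shows. Statements on the series, on what has been measured and on what is new or still open speak of the compounds shown alone.

Among the compounds with values here, compound 2 `CCCCOC(=O)OCC1OC(n2cc(C)c(=O)[nH]c2=O)CC1N=[N+]=[N-]` stands highest of the two numbers measured so far in an ADME assay on the whole organism (serum) with Homo sapiens as the target (on this read-out lower numbers stand for a shorter-lived compound and higher numbers for a longer-lived compound), where compound 2 gives 0.15 h. Within the data shown here, its only measured neighbour, compound 1 `Cc1cn(C2CC(N=[N+]=[N-])C(COC(=O)OCCCCCCCCO)O2)c(=O)[nH]c1=O`, gives 0.0333 h in this assay, and the step of a 4.5-fold higher number from compound 1 to compound 2 (0.65 log units; beyond the scatter) is the single measured change that bears on what follows. Compound 3 `Cc1cn(C2CC(N=[N+]=[N-])C(COC(=O)OCCCCCO)O2)c(=O)[nH]c1=O` differs from compound 2 by hydroxymethyl in place of hydrogen on a saturated chain carbon, four bonds along the chain from an oxygen next to a carbonyl group, which makes compound 3 resemble compound 1, whose chain also carries a hydroxyl, though the chain of compound 3 is shorter. A downward step is therefore expected, a 2.1-fold lower number from compound 2 to compound 3 (0.33 log units; beyond the scatter), smaller than the measured one. Compound 3 is expected to give 0.07 h, within 0.03 h to 0.16 h.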

Compound 3, half-life: 0.267 h
For compound 3 the middle estimate is 3.8-fold (0.58 log units) below the measured one; measured number outside the range, above it.
By their numbers in this assay, from the lowest: compound 1; then compounds 2 and 3 (each within the scatter of the next).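

In this assay, hydroxymethyl in place of hydrogen at this chain carbon gives a 1.8-fold higher number from compound 2 to compound 3 (0.25 log units; within the scatter), so a hydroxyl on the chain does not by itself go with the low number of compound 1. The two hydroxyl-bearing chains do differ, with an 8.0-fold higher number from compound 1 to compound 3 (0.90 log units; beyond the scatter), and here the change is in chain length. No measurement at hand explains these numbers. The compounds shown leave open whether an amine or a carboxylic acid in place of the hydroxymethyl would behave like the hydroxymethyl itself.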